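Swapping Bromine for Methyl on a Weak Inhibitor

This account rests on a few compounds, and the source may have more. Where it says the series, first, only, none or still open, it means among the compounds named here.

Compound 1 `COc1ccc(/C=C/C(=O)c2c(C)[n+]([O-])c3ccccc3[n+]2[O-])cc1OC` and compound 2 `Cc1c(C(=O)/C=C/c2ccc(Br)cc2)[n+]([O-])c2ccccc2[n+]1[O-]` share the same core. In a functional assay on MOLT-4 cells (Homo sapiens) for inhibition, with a stated time of 3 days (on this read-out higher numbers stand for weaker inhibition and lower numbers for stronger inhibition), compound 1 gives 18500 nM, and compound 2 gives 17100 nM, the lower of the two numbers, though its gap to compound 1 lies within the usual scatter. Compound 3 `Cc1ccc(/C=C/C(=O)c2c(C)[n+]([O-])c3ccccc3[n+]2[O-])cc1` has not yet been measured; it carries methyl in place of bromo on an aromatic carbon. For the measured compounds named here, no step between measured compounds is known, and the two measured numbers sit close together, so the step is expected to stay within the scatter, as a 1.2-fold higher number from compound 2 to compound 3 (0.07 log units; within the scatter). Compound 3 is therefore estimated at 20000 nM, between 8000 nM and 50000 nM.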

Compound 3, half-maximal inhibitory concentration: 8400 nM
Compound 3: middle estimate off by 2.4-fold (0.38 log units), on the high side; the range from low to high includes it.
By their numbers in this assay, from the lowest: compound 3; then compounds 2 and 1 (each within the scatter of the next).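

In this assay, for the compounds shown here, this is the first step between two measured compounds that differ in one place: methyl in place of bromo gives a 2.0-fold lower number from compound 2 to compound 3 (0.31 log units; beyond the scatter) and so moves the number modestly, but beyond the scatter. The position on the aromatic carbon para to a large group therefore responds to a change of a single heavy atom. No available evidence explains this difference.

Going by these compounds, how an amine, a carboxylic acid or a longer chain at this position would read remains open. A single step also cannot show whether the same swap would behave alike on other compounds.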